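Fluorophenyl to Thiophen-2-yl: What Inhibition to Expect

A few compounds are considered here, and "the series" means these few. Any claim that something is new, unique, unknown or untested is made for them only; others in the source may bear on it.

Compound 1 `Fc1ccc(-c2cn3ccnc3c(-c3ccc4ncn(C5CCCCC5)c4c3)n2)cc1` stands second highest of the three compounds measured in a functional assay on HCT-15 cells (Homo sapiens) for inhibition, read by sulforhodamine B assay, with a stated time of 48 h, tested at 10 uM (a lower number here means less inhibition, a higher number more inhibition at the concentration tested (going by the name of the read-out)), where compound 1 gives 7.59%. Compound 2 `c1cn2cc(-c3ccsc3)nc(-c3ccc4ncn(C5CCCCC5)c4c3)c2n1` gives 1.37%, and compound 3 `COc1ccccc1-c1cn2ccnc2c(-c2ccc3ncn(C4CCCCC4)c3c2)n1` gives 33.6%. The change from the fluorophenyl compound to the thiophenyl compound was a number 6.2 percentage points lower from compound 1 to compound 2 (within the scatter), whereas bringing in a 2-methoxyphenyl gave a number 26 percentage points higher from compound 1 to compound 3 (beyond the scatter) and a number 32.2 percentage points higher from compound 2 to compound 3 (beyond the scatter).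

Compound 4 `c1csc(-c2cn3ccnc3c(-c3ccc4ncn(C5CCCCC5)c4c3)n2)c1` differs from compound 1 in one place: thiophen-2-yl in place of 4-fluorophenyl on an aromatic carbon. Among the measured compounds shown here, the measured step that bears most directly on this change is the one to compound 2, since both thiophen-3-yl and thiophen-2-yl are thiophenyl groups on the same shared core. Because that step was a number 6.2 percentage points lower from compound 1 to compound 2 (within the scatter), the step to compound 4 is expected to stay within the scatter as well, at most slightly downward, so that a number 2.6 percentage points lower from compound 1 to compound 4 (within the scatter) is the estimated step. Compound 4 is therefore expected to give 5% in this assay, with a range from -8% to 20%.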

Compound 4, a percentage reported as inhibition, at one concentration (the size of the read-out at that concentration, not a potency): 2.33%
For compound 4 the middle estimate is 2.7 percentage points above the measured one, and the stated range covers the measured number.
By their numbers in this assay, from the lowest: compounds 2, 4 and 1 (each within the scatter of the next); then compound 3.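

Changing thiophen-3-yl to thiophen-2-yl gave a number 1 percentage points higher from compound 2 to compound 4 (within the scatter) and so did not separate the two thiophenyl groups at this position. In this assay, putting thiophen-2-yl in place of 4-fluorophenyl gave a number 5.3 percentage points lower from compound 1 to compound 4 (within the scatter) and so matched, with a second thiophenyl group, what compound 2 had shown. Putting thiophen-2-yl in place of 2-methoxyphenyl gave a number 31.3 percentage points lower from compound 3 to compound 4 (beyond the scatter) so that compound 3 alone stands apart among these four compounds.

Going by these compounds, whether an amine, a carboxylic acid or a longer chain at this position would give a number near that of compound 3 or near those of the other three stays open. The compounds shown come with no evidence on why 2-methoxyphenyl stands apart from the other groups.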